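From Methoxy to Fluoro on an Aromatic Carbon

The source may hold more compounds than are shown below. What is called first, only, known or untested is meant among the compounds shown, and "the series" means these compounds.

In a functional assay on HCT-116 cells (Homo sapiens) for antiproliferative activity, read by MTT assay, with a stated time of 72 h (a lower number here means a stronger inhibitor, a higher number a weaker inhibitor), compound 2 `C=CC(=O)Nc1nc(-c2ccccc2OC)cs1` gives only a limit, > 30000 nM. Compound 3 `C=CC(=O)Nc1nc(-c2ccccc2F)cs1` has fluoro in place of methoxy on an aromatic carbon, ortho to a large group (fluoro in place of methoxy on an aromatic carbon). Compound 1 `C=CC(=O)Nc1nc(-c2ccccc2)cs1`, with hydrogen instead of methoxy, gives 18600 nM. Among the compounds with values here, the one measured step that bears on this change is an at least 1.6-fold higher number from compound 1 to compound 2 (0.20 log units; that floor lies within the scatter), so it offers only a weak guide. On the strength of that step, a small move towards a lower number is expected, an at least 1.5-fold lower number from compound 2 to compound 3 (0.17 log units; that floor lies within the scatter). Compound 3 is estimated at 20000 nM, with a range of 8000 nM to 30000 nM.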

Compound 3, half-maximal inhibitory concentration: 20400 nM
Compound 3: middle estimate off by 1.0-fold (0.01 log units), on the low side; the range from low to high includes it.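

Putting fluoro in place of methoxy on this aromatic carbon, ortho to a large group, gives an at least 1.4-fold lower number from compound 2 to compound 3 (0.16 log units; that floor lies within the scatter) in this assay. Putting fluoro in place of hydrogen gives a 1.1-fold higher number from compound 1 to compound 3 (0.04 log units; within the scatter), so the two groups cannot be told apart here. Compound 2 holds only a limit, so the true distance of methoxy from either group stays unknown: the limit of > 30000 nM in this assay, at which 1 of the 3 values shown sits.

As far as these compounds go, whether chloro or an amine at this place would move the number beyond the usual scatter remains open.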